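The compounds below may be only part of what the source reports. "The series", "measured", "known", "first", "only" and "open" are said of these compounds alone.

Working notes on the series. In a functional assay on PANC-1 cells (Homo sapiens) for antiproliferative activity, read by CCK-8 assay, with a stated time of 24 h (a higher number here means a weaker inhibitor, a lower number a stronger inhibitor), compound 1 `CC(C)(O)C1Cc2cc(C[C@H]3OC(=O)C(O)=C3c3ccc(O)cc3)ccc2O1` gives > 20000 nM, which is a limit of the assay and not a number. Going by the values given here, compound 2 `COC(=O)[C@]1(Cc2ccc(O)c(CC=C(C)C)c2)OC(=O)C(O)=C1c1ccc(O)c(CC=C(C)C)c1` gives 5300 nM, the only true number so far, so it is the sole numeric reference point. The next compound to read is compound 3 `COC(=O)[C@]1(Cc2ccc(O)c(CC=C(C)C)c2)OC(=O)C(O)=C1c1ccccc1`: phenyl in place of 4-hydroxy-3-(3-methylbut-2-en-1-yl)phenyl on a double-bonded ring carbon. The methoxycarbonyl group stays. Among the compounds with values here, no measured pair isolates this change, so the expectation is a judgement from compound 2 at 5300 nM alone. A moderate loss of strength in this assay is expected, and a result reported only as a limit remains possible. The estimated change is a 2.1-fold higher number from compound 2 to compound 3 (0.32 log units; beyond the scatter). For compound 3 the expected value is 11000 nM, with an estimated range of 5000 nM to 20000 nM.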

Compound 3, half-maximal inhibitory concentration: 9400 nM
For compound 3 the middle estimate is 1.2-fold (0.07 log units) above the measured one; low and high end bracket the measured number.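

Going by these compounds alone, this is the first reading at this position, on a double-bonded ring carbon of the five-membered ring. In this assay, phenyl in place of 4-hydroxy-3-(3-methylbut-2-en-1-yl)phenyl gives a 1.8-fold higher number from compound 2 to compound 3 (0.25 log units; within the scatter), with the methoxycarbonyl group held constant. With the hydroxy group and the 3-methylbut-2-en-1-yl chain both gone, the read-out stays a true number, and the series now has two numeric reference points, both clear of the limit of the assay: the limit of > 20000 nM in this assay, at which 1 of the 3 values shown sits.

The hydroxy group and the 3-methylbut-2-en-1-yl chain leave together in this step, and their separate contributions remain unread. Also open, as far as these compounds go, is how a carboxylic acid in place of the methoxycarbonyl group, or an amine on the phenyl ring, would read in this assay.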